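Hydroxyl pattern on the aryl ring and BGC-823 cytotoxicity

The source may hold more compounds than are shown below. What is called first, only, known or untested is meant among the compounds shown, and "the series" means these compounds.

The measured compounds:
compound 1, `O=C(CSc1nnc(-c2ccncc2)o1)N/N=C/c1ccc(F)cc1`, 17800 nM
compound 2, `O=C(CSc1nnc(-c2ccncc2)o1)N/N=C/c1ccccc1O`, 6160 nM

Of the compounds shown here, two sharing one core have been measured in a functional assay on BGC-823 cells (Homo sapiens) for cytotoxicity, read by MTT assay, with a stated time of 48 h; a lower number here means a stronger inhibitor, a higher number a weaker inhibitor. Compound 1 gives 17800 nM. Compound 2 gives 6160 nM, the lowest of the two numbers; the nearest neighbour is compound 1, and the step of a 2.9-fold lower number from compound 1 to compound 2 (0.46 log units; beyond the scatter) lies beyond the scatter.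

Compound 3, `O=C(CSc1nnc(-c2ccncc2)o1)N/N=C/c1ccc(O)c(O)c1`, remains to be measured in this assay. It differs from compound 2 in one place: 3,4-dihydroxyphenyl in place of 2-hydroxyphenyl on a carbon with a double bond to nitrogen. Among the measured compounds shown here, only one measured step bears on this change, and only loosely, since a 2.9-fold lower number from compound 1 to compound 2 (0.46 log units; beyond the scatter) concerns the exchange of 4-fluorophenyl for 2-hydroxyphenyl rather than a shift from one hydroxyl to two hydroxyls. That step was modest in size. Going from compound 2 to compound 3 no large step is expected in either direction; a small move toward a lower number is taken as the central guess, as a 1.4-fold lower number from compound 2 to compound 3 (0.14 log units; within the scatter), with the range kept wide. Compound 3 is therefore estimated at 4500 nM, between 1500 nM and 14000 nM.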

Compound 3, half-maximal inhibitory concentration: 1260 nM
For compound 3 the middle estimate is 3.6-fold (0.55 log units) above the measured one; measured number outside the range, below it.
By their numbers in this assay, from the lowest: compound 3; then compound 2; then compound 1.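

At the carbon with a double bond to nitrogen, the exchange of 2-hydroxyphenyl for 3,4-dihydroxyphenyl in this assay moves the number further in the same direction as the earlier step (a 4.9-fold lower number from compound 2 to compound 3 (0.69 log units; beyond the scatter)), so the aryl group at this place can still change the read-out when a fluorine-free ring is already present. Measured against the 4-fluorophenyl compound, the same group gives a step printed as large (a 14-fold lower number from compound 1 to compound 3 (1.15 log units; beyond the scatter)), and the order of the three compounds places 3,4-dihydroxyphenyl at the low end, with 2-hydroxyphenyl in the middle and 4-fluorophenyl at the high end. Nothing among the available data speaks to why this exchange lowers the number, and the result stands as an observation only.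

The exchange alters the number of hydroxyl groups and their places on the ring in a single move, from 1 to 2 hydrogen-bond donors, so these compounds cannot tell how much of the step belongs to either change. From the compounds shown here alone, whether the hydroxyl groups themselves matter also stays open, as these three compounds do not show how a methoxy group or an amine would read at the same places on the ring.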